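Sulfonamide nitrogen swap: compound 2 to compound 3

The source may report more compounds than this note shows. Statements on the series, on what has been measured and on what is new or still open speak of the compounds shown alone.

- compound 1 `Cc1cc(C)nc(NS(=O)(=O)c2ccc(Nc3nncc4ccccc34)cc2)n1`: 7.9 nM
- compound 2 `O=S(=O)(Nc1nccs1)c1ccc(Nc2nncc3ccccc23)cc1`: 56 nM

In a functional assay on COLO 205 cells (Homo sapiens) for antiproliferative activity, read by sulforhodamine B assay, with a stated time of 72 h (on this read-out higher numbers stand for weaker inhibition and lower numbers for stronger inhibition), compound 2 gives 56 nM, the higher number of the two measured and so the weaker inhibition. Compound 3 `Cc1cc(NS(=O)(=O)c2ccc(Nc3nncc4ccccc34)cc2)no1` has not yet been measured. It carries 5-methyl-1,2-oxazol-3-yl in place of 1,3-thiazol-2-yl on a sulfonamide nitrogen. Going by the values given here, one measured step bears on this change, at the same place: a 7.1-fold higher number from compound 1 to compound 2 (0.85 log units; beyond the scatter). That step involves a different pair of groups and gives no direction here. The leaving and entering groups are each a five-membered aromatic ring with 2 hetero atoms. A smaller step than a 7.1-fold higher number from compound 1 to compound 2 (0.85 log units; beyond the scatter) is therefore expected in this assay, with no firm direction and possibly none beyond the scatter. Compound 3 is estimated at 40 nM, with an expected range of 12 nM to 130 nM. This is an expected 1.4-fold lower number from compound 2 to compound 3 (0.15 log units; within the scatter).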

Compound 3, half-maximal inhibitory concentration: 43 nM
Compound 3: the middle estimate sits 1.1-fold (0.03 log units) below what was measured; the measured number falls inside the stated range.
By their numbers in this assay, from the lowest: compound 1; then compounds 3 and 2 (each within the scatter of the next).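

In this assay, 5-methyl-1,2-oxazol-3-yl in place of 1,3-thiazol-2-yl on a sulfonamide nitrogen gives a 1.3-fold lower number from compound 2 to compound 3 (0.11 log units; within the scatter), so this exchange of one five-membered aromatic ring for another, with its added methyl, separates compound 2 and compound 3 by no more than the scatter. The second five-membered ring also stays apart from the 4,6-dimethylpyrimidin-2-yl group, with a 5.4-fold higher number from compound 1 to compound 3 (0.74 log units; beyond the scatter) alongside a 7.1-fold higher number from compound 1 to compound 2 (0.85 log units; beyond the scatter), leaving compound 1 with the lowest number of the three. No evidence on the origin of these differences is available.

Open, as far as these compounds go, is whether the advantage of compound 1 rests on the six-membered ring or on its two methyl groups, which an unsubstituted pyrimidin-2-yl would separate. Also open, from the compounds shown here alone, is how a pyridin-2-yl or a plain phenyl on the sulfonamide nitrogen would compare.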